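Sulfonyl change from oxetan-3-yl to pyrrolidin-1-yl

The source may report more compounds than this note shows. Statements on the series, on what has been measured and on what is new or still open speak of the compounds shown alone.

Among the measured compounds shown here, in an ADME assay on microsomes from liver (Homo sapiens) for metabolic stability, read by LC-MS, with a stated time of 40 min, tested at 0.5 uM (on this read-out lower numbers stand for slow clearance and higher numbers for fast clearance), compound 3 `O=C(Nc1cccc(S(=O)(=O)C2COC2)c1)c1cccnc1N1CCC2(CC1)CC2` gives 183 mL.min-1.g-1 as the only number so far. Compound 1 `CC(C)(C)NS(=O)(=O)c1cccc(NC(=O)c2cccnc2N2CCC3(CC2)CC3)c1` reads > 399 mL.min-1.g-1 in this assay, which is a limit and not a number. Compound 2 `O=C(Nc1cccc(S(=O)(=O)C2CCCC2)c1)c1cccnc1N1CCC2(CC1)CC2` reads > 399 mL.min-1.g-1, likewise a limit. The change to compound 4 `O=C(Nc1cccc(S(=O)(=O)N2CCCC2)c1)c1cccnc1N1CCC2(CC1)CC2` is pyrrolidin-1-yl in place of oxetan-3-yl on a sulfonyl sulfur on a sulfonyl sulfur. For the measured compounds named here, two measured steps bear on it, both bringing oxetan-3-yl in: an at least 2.1-fold lower number from compound 1 to compound 3 (0.33 log units; beyond the scatter) and an at least 2.1-fold lower number from compound 2 to compound 3 (0.33 log units; beyond the scatter), each beyond the scatter. Here oxetan-3-yl leaves again, so the expected result, read from those two steps in reverse, is a 2.0-fold higher number from compound 3 to compound 4 (0.29 log units; within the scatter), toward faster clearance. A report of only a limit is about as likely as a number. For compound 4 the estimate is 360 mL.min-1.g-1 (expected range 190 mL.min-1.g-1 to 650 mL.min-1.g-1).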

Compound 4, intrinsic clearance in microsomes: > 399 mL.min-1.g-1
Compound 4: a limit, no number; the forecaster's own chance of this, stated with the estimate: 50%; middle value at least 1.1-fold (0.04 log units) from the limit.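

The result gives an at least 2.1-fold higher number from compound 3 to compound 4 (0.33 log units; beyond the scatter) in this assay, so the drop in clearance seen with oxetan-3-yl on the sulfonyl sulfur is now lost with pyrrolidin-1-yl as well. Among the four groups shown, only oxetan-3-yl gives a number, whereas (tert-butyl)amino, cyclopentyl and pyrrolidin-1-yl all give limits. The steps among compound 1, compound 2 and compound 4 cannot be read, as all three stop at the same limit: the limit of > 399 mL.min-1.g-1 in this assay, at which 3 of the 4 values shown sit.

Still open, from the compounds shown here alone, is whether morpholin-4-yl or tetrahydropyran-4-yl on the same sulfonyl sulfur would give a number or another limit.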